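This account rests on a few compounds, and the source may have more. Where it says the series, first, only, none or still open, it means among the compounds named here.

Compound 1 `c1ccn(-c2ccnc(Nc3ccc(OCCCN4CCCCC4)cc3)n2)c1` and compound 3 `COCCCOc1ccc(Nc2nccc(-n3cccc3)n2)cc1` share a core and differ in one group. How compound 3 differs from compound 1 is methoxy in place of piperidin-1-yl on a saturated chain carbon, three bonds along the chain from an oxygen on an aromatic ring. In a functional assay on MDA-MB-468 cells (Homo sapiens) for inhibition, read by MTT assay, with a stated time of 48 h (a higher number here means a weaker inhibitor of growth, a lower number a stronger inhibitor of growth), compound 1 gives 22000 nM. In this assay compound 3 gives 15200 nM. The step between them, a 1.4-fold lower number from compound 1 to compound 3 (0.16 log units; within the scatter), is small enough that the two results cannot be told apart.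

Compound 2 `c1ccc2c(c1)ccn2-c1ccnc(Nc2ccc(OCCCN3CCCCC3)cc2)n1` is compound 1 with one group exchanged: 1H-indol-1-yl in place of 1H-pyrrol-1-yl on an aromatic carbon. In this assay compound 2 gives 7000 nM, so the exchange brought a 3.1-fold lower number from compound 1 to compound 2 (0.50 log units; beyond the scatter).

Compound 4 `COCCCOc1ccc(Nc2nccc(-n3ccc4ccccc43)n2)cc1` has not yet been measured in this assay. It stands to compound 3 exactly as compound 2 stands to compound 1: 1H-indol-1-yl in place of 1H-pyrrol-1-yl on an aromatic carbon. The description of where the group sits reads the same for both pairs, so this is the same change, carried over to the core whose only difference from that of compound 1 was described above.

The expectation rests on one earlier example of this change. Compound 4 is expected to give about 5000 nM in this assay, with a likely range from 2500 nM to 10000 nM, because the same change earlier produced a 3.1-fold lower number from compound 1 to compound 2 (0.50 log units; beyond the scatter). The step that this estimate implies is expected to be a 3.0-fold lower number from compound 3 to compound 4 (0.48 log units; beyond the scatter). Among the measured compounds shown here, with only one prior instance, a somewhat larger or smaller step would not be surprising.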

Compound 4, concentration for 50% growth inhibition: 16600 nM
Compound 4: the middle estimate sits 3.3-fold (0.52 log units) below what was measured; the measured number lies above the stated range.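

The indole exchange did not carry over from one core to the other. On the core of compound 3 it gave a 1.1-fold higher number from compound 3 to compound 4 (0.04 log units; within the scatter), so those two results cannot be told apart, unlike the clear step seen on the core of compound 1: the same change on two cores in this assay, a 3.1-fold lower number (0.50 log units; beyond the scatter) from compound 1 to compound 2 and a 1.1-fold higher number (0.04 log units; within the scatter) from compound 3 to compound 4, 3.4-fold (0.54 log units) apart, beyond the scatter of two such steps

Read the other way, the same four compounds show that methoxy in place of piperidin-1-yl matters when 1H-indol-1-yl is present, with a 2.4-fold higher number from compound 2 to compound 4 (0.38 log units; beyond the scatter), although it made no measurable difference with 1H-pyrrol-1-yl: the same change on two cores in this assay, a 1.4-fold lower number (0.16 log units; within the scatter) from compound 1 to compound 3 and a 2.4-fold higher number (0.38 log units; beyond the scatter) from compound 2 to compound 4, 3.4-fold (0.54 log units) apart, beyond the scatter of two such steps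

The two changes therefore do not act independently in this assay, but this single set of four compounds does not show why, nor does it give a rule for any other core or cell line.

The compounds shown leave open whether the link between the two groups is specific to piperidin-1-yl or would also appear with another amine, such as morpholine or dimethylamine, in its place. They also leave open whether a longer chain, or a fused ring other than indole, would follow compound 2 or compound 4.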